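From Methoxy to Hydroxy on the Shared Core

This account rests on a few compounds, and the source may have more. Where it says the series, first, only, none or still open, it means among the compounds named here.

Of the compounds shown here, three built on one shared core have been tested in a functional assay on NCI-H460 cells (Homo sapiens) for inhibition, read by MTT assay, with a stated time of 48 h; a lower number here means a stronger inhibitor of growth, a higher number a weaker inhibitor of growth. Compound 1 `COc1ccc(-c2cc(-c3ccccc3-c3ccccc3)n[nH]2)cc1` carries a 4-methoxyphenyl and gives 730 nM. Compound 2 `COc1ccccc1-c1cc(-c2ccccc2-c2ccccc2)n[nH]1` carries a 2-methoxyphenyl and gives 9100 nM. Compound 3 `COc1cccc(-c2cc(-c3ccccc3-c3ccccc3)n[nH]2)c1` carries a 3-methoxyphenyl and gives 8700 nM. Among these three numbers compound 3 stands second highest; its value and that of compound 2 lie within the scatter of one another, as the step of a 1.0-fold lower number from compound 2 to compound 3 (0.02 log units; within the scatter) shows, while the step of a 12-fold higher number from compound 1 to compound 3 (1.08 log units; beyond the scatter) is large. Compound 4 `Oc1ccc(-c2cc(-c3ccccc3-c3ccccc3)n[nH]2)cc1` has not yet been measured. It differs from compound 3 in one place: 4-hydroxyphenyl in place of 3-methoxyphenyl on an aromatic carbon. For the measured compounds named here, no measured pair compares a methoxy group with a hydroxy group, so that part of the change has no direct precedent. What does bear on it is the prefix in the group name: the steps of a 12-fold higher number from compound 1 to compound 2 (1.10 log units; beyond the scatter) and a 12-fold higher number from compound 1 to compound 3 (1.08 log units; beyond the scatter) both show that leaving the 4-methoxyphenyl of compound 1 cost a large amount, so a 4-hydroxyphenyl, which resembles the group in compound 1, is expected to bring the number down sharply in this assay. Compound 4 is therefore expected to give about 1000 nM, within 300 nM to 4000 nM, an expected step of an 8.7-fold lower number from compound 3 to compound 4 (0.94 log units; beyond the scatter).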

Compound 4, concentration for 50% growth inhibition: 6900 nM
Estimate against measurement, compound 4: 6.9-fold (0.84 log units) below, and the stated range ends below it.
By their numbers in this assay, from the lowest: compound 1; then compounds 4, 3 and 2 (each within the scatter of the next).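

For the compounds shown here, the methyl on the oxygen turns out to matter on its own: swapping it for hydrogen is the only change between compound 1 and compound 4, and in this assay it gives a 9.5-fold higher number from compound 1 to compound 4 (0.98 log units; beyond the scatter), so the 4-hydroxyphenyl does not keep the low number of the 4-methoxyphenyl even though the oxygen stays on the same ring carbon. Compound 4 instead falls in with the other two compounds, with a 1.3-fold lower number from compound 3 to compound 4 (0.10 log units; within the scatter) and a 1.3-fold lower number from compound 2 to compound 4 (0.12 log units; within the scatter), which leaves compound 1 as the only one of the four set apart from the rest. Nothing available here explains why losing this one methyl has so large an effect on the number.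

The compounds shown leave open whether a longer chain on that oxygen, such as ethyl, or an amine in place of the oxygen, would hold the number of compound 1 or lose it. Going by these compounds alone, they also leave open whether hydrogen in place of methyl would change anything on the 3-methoxyphenyl of compound 3 or the 2-methoxyphenyl of compound 2, where the same swap has no pair to read.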